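The compounds below may be only part of what the source reports. "The series", "measured", "known", "first", "only" and "open" are said of these compounds alone.

Measured so far:
compound 1, `CC(C)[C@@H](NC(=O)CCc1ccc(F)cc1)C(=O)N1CCC(c2ccc(Cl)cc2)CC1`, gives 70 nM in an assay on THP-1 cells for displacement of a labelled ligand from C-C chemokine receptor type 1 (Homo sapiens); a lower number here means a stronger inhibitor, a higher number a weaker inhibitor
compound 2, `CC(C)[C@@H](NC(=O)C1CCCC1)C(=O)N1CCC(c2ccc(Cl)cc2)CC1`, gives 70 nM in this assay

Compound 2 stands level with compound 1: the step of no change at the digits printed from compound 1 to compound 2 (within the scatter) shows that replacing the arylethyl group on the carbonyl carbon with a small saturated ring left the binding unchanged. Compound 3, `Cc1cccc(CCC(=O)N[C@@H](C(=O)N2CCC(c3ccc(Cl)cc3)CC2)C(C)C)c1`, takes the next step: 2-(3-methylphenyl)ethyl in place of cyclopentyl on a carbonyl carbon. This is in effect a return to the kind of group found in compound 1, now with a methyl group on the aromatic ring in place of its fluorine. For the measured compounds named here, the one step that bears on it, from compound 1 to compound 2, was flat, so the reverse kind of exchange is expected to be flat as well, with no movement in this assay beyond the scatter. Compound 3 is therefore expected to give about 70 nM, with a likely range from 25 nM to 200 nM. The step of no change at the digits printed from compound 2 to compound 3 (within the scatter) is the estimated consequence, essentially no change.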

Compound 3, half-maximal inhibitory concentration: 22 nM
Compound 3: middle estimate off by 3.2-fold (0.50 log units), on the high side; measured number below the stated range.
By their numbers in this assay, from the lowest: compound 3; then compounds 1 and 2 (each within the scatter of the next).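

Here an arylethyl group on this carbonyl carbon does not simply match cyclopentyl: in this assay the change gives a 3.2-fold lower number from compound 2 to compound 3 (0.50 log units; beyond the scatter) and so reaches beyond the flat result seen earlier. The group on the aromatic ring also counts, since 3-methylphenyl in place of 4-fluorophenyl gives a 3.2-fold lower number from compound 1 to compound 3 (0.50 log units; beyond the scatter) even though both compounds keep the same two-carbon link to the carbonyl. No measured property is available to account for either difference.

The compounds shown leave open whether this difference follows the methyl group itself or its place on the ring, a question that a 3-fluorophenyl or a 4-methylphenyl group could help settle. From the compounds shown here alone, it is also open how an amine or a carboxylic acid on that ring would fare in this assay here.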